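This account rests on a few compounds, and the source may have more. Where it says the series, first, only, none or still open, it means among the compounds named here.

Compound 1 `COc1cc(Cl)ccc1C[C@@H](C)C(=O)N1CCN(c2ccc(C)cc2[C@@H](N)CC(C)C)CC1` was tested in an assay on HEK293 cells for displacement of a labelled ligand from Melanocortin receptor 4 (Homo sapiens) (on this read-out lower numbers stand for stronger inhibition and higher numbers for weaker inhibition), where compound 1 gives 8.1 nM. Going by the values given here, of the two compounds measured so far, it has the lower number; the other, compound 2 `CC(C)C[C@H](N)c1cc(C(F)(F)F)ccc1N1CCN(C(=O)COc2ccc(O)cc2)CC1`, gives 4600 nM in this assay, a far higher number than compound 1 and well beyond the usual scatter. Compound 3 `Cc1ccc(N2CCN(C(=O)[C@H](C)Cc3ccc(Cl)cc3F)CC2)c([C@@H](N)CC(C)C)c1` has not yet been measured. It is made from compound 1 by a single change: fluoro in place of methoxy on an aromatic carbon. Put another way, the 4-chloro-2-methoxybenzyl becomes a 4-chloro-2-fluorobenzyl, while the rest of the shared core is kept. Among the compounds with values here, no pair of measured compounds differing in only one place is available here, so the size of this step can only be expected, not read off. The step is expected to be small, a 1.9-fold higher number from compound 1 to compound 3 (0.27 log units; within the scatter), toward a somewhat higher number and close to the edge of the scatter. Compound 3 is therefore expected to give about 15 nM in this assay, within a range from 4 nM to 60 nM.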

Compound 3, inhibition constant: 20 nM
Compound 3: the middle estimate sits 1.3-fold (0.12 log units) below what was measured; the range from low to high includes it.
By their numbers in this assay, from the lowest: compound 1; then compound 3; then compound 2.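

Methoxy on this aromatic carbon, ortho to a large group, is not needed for a low number in this assay, since compound 3 still gives 20 nM. Even so, replacing it with fluoro carries a modest cost, (a 2.5-fold higher number from compound 1 to compound 3 (0.39 log units; beyond the scatter)), so the group at this position does influence the result. The change removes two heavy atoms and a hydrogen-bond acceptor and adds one fluorine, but nothing available explains the higher number or shows which part of the change matters.

As far as these compounds go, it remains open how an ethoxy group, a nitrile or a hydroxyl group on this same carbon would compare with methoxy and fluoro. Whether this step would be the same size without the 4-chloro group is also unknown.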